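From Methoxy to Hydrogen at the Assay Limit

The source may report more compounds than this note shows. Statements on the series, on what has been measured and on what is new or still open speak of the compounds shown alone.

Compound 1 (`C/C(=C\CC/C(C)=C/CC[C@@H]1[C@@]2(C)CCC(=O)C(C)(C)[C@H]2CC[C@@]1(C)O)CC/C=C(\C)C(=O)OCc1cn(-c2ccc([N+](=O)[O-])cc2)nn1`): limit > 150000 nM
Compound 2 (`COc1ccc(-n2cc(COC(=O)/C(C)=C/CC/C(C)=C/CC/C(C)=C/CC[C@@H]3[C@@]4(C)CCC(=O)C(C)(C)[C@H]4CC[C@@]3(C)O)nn2)cc1`): limit > 150000 nM

In a functional assay on A549 cells (Homo sapiens) for antiproliferative activity, read by MTT assay, with a stated time of 48 h (on this read-out lower numbers stand for stronger inhibition and higher numbers for weaker inhibition), compound 2 gives the limit > 150000 nM, which is not a number. Going by the values given here, the series so far offers only (the limit of > 150000 nM in this assay, at which 2 of the 2 values shown sit), so no true potency is known for any compound. Compound 3 (`C/C(=C\CC/C(C)=C/CC[C@@H]1[C@@]2(C)CCC(=O)C(C)(C)[C@H]2CC[C@@]1(C)O)CC/C=C(\C)C(=O)OCc1cn(-c2ccccc2)nn1`) carries hydrogen in place of methoxy on an aromatic carbon, turning 4-methoxyphenyl to phenyl (hydrogen in place of methoxy on an aromatic carbon). Among the compounds with values here, the one measured step that bears on this change is a step that the two limits leave unreadable from compound 1 to compound 2, with methoxy in place of nitro on an aromatic carbon. It gives no size to carry over, and neither compound 1 nor compound 2 left the limit. No change beyond the scatter is therefore expected in this assay, and no direction can be favoured. The expected step is a step that the limit leaves unreadable from compound 2 to compound 3. Compound 3 is estimated at 200000 nM, within an expected range of 100000 nM to 400000 nM, and will most likely be reported only as a limit.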

Compound 3, half-maximal inhibitory concentration: > 150000 nM
Compound 3 ended at the assay's limit; the forecaster's own chance of this, stated with the estimate: 85%; the middle value is on the limit's open side.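

Compound 3 also returns a limit and not a number, so no step can be read among compound 1, compound 2 and compound 3: the limit of > 150000 nM in this assay, at which 3 of the 3 values shown sit. On these data alone, whether nitro, methoxy and hydrogen on the aromatic ring differ at all in this assay stays open.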